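Swapping Two Ring Stereocentres in a Weak Growth Inhibitor

The source may report more compounds than this note shows. Statements on the series, on what has been measured and on what is new or still open speak of the compounds shown alone.

Measured compounds in a functional assay on Malme-3M cells (Homo sapiens) for inhibition; a higher number here means a weaker inhibitor of growth, a lower number a stronger inhibitor of growth:
Compound 1, `C=C1CCCC(C)(C)C1(O)CC/C(C)=C/CC[C@]1(C)CC[C@@H]([C@@H](C)C(=O)OC)OO1`, gives > 17500 nM, a limit of the assay.
Compound 2, `C=C1CCCC(C)(C)C1CC[C@]1(C)CC[C@H]([C@@H](C)C(=O)OC)OO1`, gives 21000 nM.
Compound 3, `C=C1CCCC(C)(C)C1CC[C@@]1(C)CC[C@H]([C@@H](C)C(=O)O)OO1`, gives > 12500 nM, a limit of the assay.

Compound 3 stands among the weakest results in this assay: its value is a limit, as the limit of > 12500 nM in this assay, at which 1 of the 3 values shown sits, shows, and compound 1 likewise sits at a limit, as the limit of > 17500 nM in this assay, at which 1 of the 3 values shown sits, shows. Only compound 2 gives a number, and that number is high.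

Compound 4, `C=C1CCCC(C)(C)C1CC[C@]1(C)CC[C@@H]([C@@H](C)C(=O)O)OO1`, is the compound not yet measured. It differs from compound 3 as follows: the two compounds have the same atoms and bonds; at least one stereo element is drawn with a configuration in one of them and without one in the other: 2 of 4 stereo elements differ; a stereocentre at a saturated ring carbon is drawn S in compound 3 and R in compound 4; a stereocentre at a saturated ring carbon is drawn R in compound 3 and S in compound 4.

For the measured compounds named here, no measured pair differs in only one place, so no step size is known here. Going by the values given here, both limits sit close to the one number given, so no change beyond the usual scatter is expected, in either direction. Compound 4 is expected to give about 15000 nM in this assay, within 5000 nM to 45000 nM, which is the step that the limit leaves unreadable from compound 3 to compound 4 as estimated, with a fair chance that only a limit is reported.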

Compound 4, concentration for 50% growth inhibition: 3960 nM
Estimate against measurement, compound 4: 3.8-fold (0.58 log units) above; measured number outside the range, below it.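

The earlier compounds shown here held no pair differing in one place, so no step could be read. Compounds 3 and 4 have the same atoms and bonds and differ only at two stereocentres at saturated ring carbons, and in this assay this spatial change alone gives an at least 3.1-fold lower number from compound 3 to compound 4 (0.49 log units; beyond the scatter). The true size of this step may be larger, as compound 3 gives only a limit, not a number: the limit of > 12500 nM in this assay, at which 1 of the 4 values shown sits.

From the compounds shown here alone, the two stereocentres change together, so it remains open whether one of them alone accounts for the step, or whether both are needed. It is also open whether the same stereochemical preference would hold with an amide or a primary alcohol in place of the carboxylic acid, and the compounds shown do not explain why the arrangement matters.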